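The source may report more compounds than this note shows. Statements on the series, on what has been measured and on what is new or still open speak of the compounds shown alone.

Working notes on the series built on the shared core of compound 1 `Nc1ccnc(-c2nn(Cc3ccccc3F)c3ncccc23)n1`. In a functional assay (aorta) with Oryctolagus cuniculus as the target (on this read-out lower numbers stand for stronger inhibition and higher numbers for weaker inhibition), compound 1 gives 270 nM; 265000 nM (2 entries); the two entries for compound 1 the several entries of compound 1 in this assay, 270 nM; 265000 nM (2 entries) lie far apart and are taken as they stand. Compound 2 `N#Cc1cnc(-c2nn(Cc3ccccc3F)c3ncccc23)nc1N` gives 391000 nM in this assay. Compound 3 `CSc1cnc(-c2nn(Cc3ccccc3F)c3ncccc23)nc1N` gives 243000 nM in this assay, the lowest of the two single numbers, with compound 2 nearest; the step of a 1.6-fold lower number from compound 2 to compound 3 (0.21 log units; within the scatter) lies within the scatter, so no order is drawn from it.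

Compound 4 `CC(C)S(=O)(=O)c1cnc(-c2nn(Cc3ccccc3F)c3ncccc23)nc1N` differs from compound 3 by isopropylsulfonyl in place of methylsulfanyl on an aromatic carbon. Among the measured compounds shown here, no measured step exchanges a methylsulfanyl for an isopropylsulfonyl; the only measured step at this position, a 1.6-fold lower number from compound 2 to compound 3 (0.21 log units; within the scatter), stayed within the scatter, and it is the only step that bears on the present change. On that basis a step of similar size is expected, a 1.0-fold higher number from compound 3 to compound 4 (0.01 log units; within the scatter), with no direction beyond the scatter. Compound 4 is therefore expected to give 250000 nM in this assay, within 60000 nM to 800000 nM. The range is set wide given the spread of the two entries for compound 1 (the several entries of compound 1 in this assay, 270 nM; 265000 nM (2 entries)).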

Compound 4, half-maximal inhibitory concentration: 517000 nM
For compound 4 the middle estimate is 2.1-fold (0.32 log units) below the measured one, within the range that was stated.
By their numbers in this assay, from the lowest: compounds 3, 2 and 4 (each within the scatter of the next, the first and the last beyond it).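

Among the compounds shown here, at this position, on the aromatic carbon ortho to an amino group and para to a large group, the exchange of methylsulfanyl for isopropylsulfonyl gives the first step beyond the scatter in this assay, with a 2.1-fold higher number from compound 3 to compound 4 (0.33 log units; beyond the scatter), and that step is modest and points towards weaker inhibition. Against the cyano group, isopropylsulfonyl gives a 1.3-fold higher number from compound 2 to compound 4 (0.12 log units; within the scatter), so no order can be drawn between those two groups, and the three compounds separate only at their two ends, with methylsulfanyl at the lower end and isopropylsulfonyl at the higher. Even that modest separation rests on single entries in an assay where one compound has given widely different numbers: the several entries of compound 1 in this assay, 270 nM; 265000 nM (2 entries).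

The compounds shown do not tell whether the step from compound 3 to compound 4 follows from the sulfonyl group or from the isopropyl chain, a question that methylsulfonyl or isopropylsulfanyl at this position would address. Going by these compounds, it also stays open whether an amine, a carboxylic acid or a longer alkyl chain here would move the number in either direction.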